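The compounds below may be only part of what the source reports. "The series", "measured", "known", "first", "only" and "open" are said of these compounds alone.

Compound 3 `O=C1c2ccccc2N(COCc2ccccc2)S(=O)(=O)N1Cc1ccccc1` stands alone among the three measured compounds in returning a number in a functional assay on HEL cells (Homo sapiens); on this read-out higher numbers stand for lower toxicity in this test and lower numbers for higher toxicity in this test: compound 3 gives 122000 nM. Compound 1 `O=C1c2ccccc2N(Cc2ccc(Cl)cc2)S(=O)(=O)N1Cc1ccccc1` gives only a limit in this assay, > 5000 nM. Compound 2 `O=C1c2ccccc2N(Cc2cccc(Cl)c2)S(=O)(=O)N1Cc1ccccc1` also gives only a limit in this assay, > 5000 nM. Because of the limit of > 5000 nM in this assay, at which 2 of the 3 values shown sit, the step that the limit leaves unreadable from compound 1 to compound 3 and the step that the limit leaves unreadable from compound 2 to compound 3 stay without a readable size. Compound 4 `O=C1c2ccccc2N(Cc2ccc(Cl)c(Cl)c2)S(=O)(=O)N1Cc1ccccc1` differs from compound 3 by 3,4-dichlorophenyl in place of benzyloxy on a saturated chain carbon bound to a sulfonamide nitrogen in a ring. Going by the values given here, no measured step bears on this change with a readable size, so the direction and size of the change are open. Compound 4 is expected to come out near 60000 nM, between 5000 nM and 200000 nM. This estimate means an expected step of a 2.0-fold lower number from compound 3 to compound 4 (0.31 log units; beyond the scatter) in this assay.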

Compound 4, minimum cytotoxic concentration: 200000 nM
Estimate against measurement, compound 4: 3.3-fold (0.52 log units) below, within the range that was stated.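

In this assay, going by these compounds alone, 3,4-dichlorophenyl in place of benzyloxy on a saturated chain carbon bound to a sulfonamide nitrogen in a ring gives the first readable step at this position, a 1.6-fold higher number from compound 3 to compound 4 (0.21 log units; within the scatter), so this read-out does not tell the two groups apart. The steps to compound 4 from compound 1 and from compound 2, each a chloro in place of hydrogen on an aromatic carbon, cannot be read because of a limit: the limit of > 5000 nM in this assay, at which 2 of the 4 values shown sit.

The compounds shown leave open how much that chloro changes the number, and whether an amine or a carboxylic acid at this place would give a step beyond the scatter.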